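The source may hold more compounds than are shown below. What is called first, only, known or untested is meant among the compounds shown, and "the series" means these compounds.

In a functional assay on IGROV-1 cells (Homo sapiens) for inhibition (on this read-out higher numbers stand for weaker inhibition of growth and lower numbers for stronger inhibition of growth), compound 2 `C=C1CCC[C@H]2[C@](C)(CC[C@]3(C)CC[C@@H]([C@@H](C)C(=O)O)OO3)[C@@H](C)CC[C@]12C` gives 100 nM, the lowest of the three numbers recorded so far. Compound 1 `C=C1CCCC(C)(C)C1CC[C@]1(C)CC[C@@H]([C@@H](C)C(=O)O)OO1` gives 1730 nM, a gap beyond the scatter, and compound 3 `CC1=C(CC/C(C)=C/CC[C@@]2(C)CC[C@@H]([C@H](C)C(=O)O)OO2)C(C)(C)CCC1` gives 43600 nM, the furthest of the three from compound 2. Compound 4 `C=C1CCC[C@H]2[C@](C)(CC[C@]3(C)CC[C@H]([C@@H](C)C(=O)O)OO3)[C@@H](C)CC[C@]12C` has not yet been measured in this assay. Its relation to compound 2 is this: the two compounds have the same atoms and bonds and differ only in configuration as drawn: 1 of 7 stereo elements differ; a stereocentre at a saturated ring carbon is drawn S in compound 2 and R in compound 4. No two measured compounds here differ in a single place, so the size of such a step has no direct precedent among the numbers shown. A modest weakening, beyond the scatter, is expected, with a 3.0-fold higher number from compound 2 to compound 4 (0.48 log units; beyond the scatter) as the estimated step. Compound 4 is accordingly expected to give about 300 nM, within a range from 70 nM to 1500 nM.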

Compound 4, concentration for 50% growth inhibition: 120 nM
For compound 4 the middle estimate is 2.5-fold (0.40 log units) above the measured one, within the range that was stated.
By their numbers in this assay, from the lowest: compounds 2 and 4 (each within the scatter of the next); then compound 1; then compound 3.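

In this assay the series gains its first comparison of two compounds that differ in one place, and the step is a 1.2-fold higher number from compound 2 to compound 4 (0.08 log units; within the scatter). Drawing this saturated ring carbon as S or R therefore leaves the growth read-out indistinguishable, which the earlier compounds could not show. Any reading of this step rests on a single change of stereocentre: the fact that compounds 2 and 4 differ only in the configuration as drawn. The compounds shown leave open whether the other stereo elements can change with as little effect. They also leave open whether a methyl ester or a primary amide could stand in place of the carboxylic acid.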